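Replacing a ring sulfonyl with a carbamoyl: permeability of compound 4

The source may report more compounds than this note shows. Statements on the series, on what has been measured and on what is new or still open speak of the compounds shown alone.

Measured so far:
- compound 1, `Cn1cncc1CN1CC(N(CC2CCN(C(=O)CC(F)(F)F)CC2)S(=O)(=O)c2ccccn2)Cc2cc(C#N)ccc21`: 0.5 10^-6 cm/s
- compound 2, `CC(C)S(=O)(=O)N1CCC(CN(C2Cc3cc(C#N)ccc3N(Cc3cncn3C)C2)S(=O)(=O)c2ccccn2)CC1`: 0.1 10^-6 cm/s
- compound 3, `CCCC(=O)N1CCC(CN(C2Cc3cc(C#N)ccc3N(Cc3cncn3C)C2)S(=O)(=O)c2ccccn2)CC1`: 0.5 10^-6 cm/s

The three compounds share one core and differ only in the group on the amine nitrogen of the six-membered non-aromatic ring. In an ADME assay on Caco-2 cells (Homo sapiens) for permeability, in the apical to basolateral direction (on this read-out higher numbers stand for higher permeability and lower numbers for lower permeability), compound 2 stands lowest of the three numbers; it lies a 5.0-fold lower number from compound 1 to compound 2 (0.70 log units; beyond the scatter) and a 5.0-fold higher number from compound 2 to compound 3 (0.70 log units; beyond the scatter). Compound 3, 0.5 10^-6 cm/s, and compound 1, 0.5 10^-6 cm/s, sit together, and the step of no change at the digits printed from compound 1 to compound 3 (within the scatter).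

Compound 4, `CCNC(=O)N1CCC(CN(C2Cc3cc(C#N)ccc3N(Cc3cncn3C)C2)S(=O)(=O)c2ccccn2)CC1`, has not yet been measured. The change from compound 2 is ethylcarbamoyl in place of isopropylsulfonyl on an amine nitrogen in a ring.

Both measured steps that start or end at compound 2 bear on this: each time the isopropylsulfonyl was exchanged for a carbonyl-bearing group, the number rose, and by a similar amount in both a 5.0-fold lower number from compound 1 to compound 2 (0.70 log units; beyond the scatter) and a 5.0-fold higher number from compound 2 to compound 3 (0.70 log units; beyond the scatter). The ethylcarbamoyl also carries a carbonyl, so a rise is expected, though the added hydrogen-bond donor makes the size less certain. Compound 4 is therefore estimated at 0.3 10^-6 cm/s, with a range of 0.1 10^-6 cm/s to 1 10^-6 cm/s, which means an expected step of a 3.0-fold higher number from compound 2 to compound 4 (0.48 log units; beyond the scatter).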

Compound 4, apparent permeability: 0.6 10^-6 cm/s
Compound 4: the middle estimate sits 2.0-fold (0.30 log units) below what was measured; the measured number falls inside the stated range.
By their numbers in this assay, from the lowest: compound 2; then compounds 1, 3 and 4 (each within the scatter of the next).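

In this assay, ethylcarbamoyl on the amine nitrogen of the six-membered non-aromatic ring gives a 6.0-fold higher number from compound 2 to compound 4 (0.78 log units; beyond the scatter), so a third carbonyl-bearing group now stands clear of the isopropylsulfonyl of compound 2. The hydrogen-bond donor that enters with ethylcarbamoyl does not set it apart from the other carbonyl-bearing groups, with a 1.2-fold higher number from compound 3 to compound 4 (0.08 log units; within the scatter) and a 1.2-fold higher number from compound 1 to compound 4 (0.08 log units; within the scatter). Among these four compounds, only compound 2 stands apart, and nothing shown here accounts for that difference.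

Compound 2 is the only sulfonyl example at this nitrogen, so the compounds shown cannot tell whether a methylsulfonyl or a phenylsulfonyl group would sit as low. On these data alone, it also remains open whether a group with no carbonyl or sulfonyl, such as a plain isopropyl or a benzyl, would fall with compound 2 or with the other three compounds.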